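The compounds below may be only part of what the source reports. "The series", "measured", "known", "first", "only" and "open" are said of these compounds alone.

Measured compounds:
compound 1 `CSc1nc(NCCCc2ccccc2)c2ccccc2n1` — 89600 nM
compound 2 `CCCCC[Se]c1nc(N)c2cccnc2n1` — 20000 nM

Among the measured compounds shown here, in a functional assay on HT-29 cells (Homo sapiens) for cytotoxicity, read by MTT assay, with a stated time of 72 h (a lower number here means a stronger inhibitor of growth, a higher number a weaker inhibitor of growth), compound 1 gives 89600 nM, the higher of the two numbers measured so far. Compound 2 gives 20000 nM, and the gap between compound 2 and compound 1 is beyond the scatter; the two differ in more than one place, so nothing in it can be assigned to a single change.

Compound 3 `CSc1nc(NCCCCc2ccccc2)c2ccccc2n1` keeps the core of compound 1 and differs from it in one place: benzyl in place of phenyl on a saturated chain carbon, three bonds along the chain from a nitrogen on an aromatic ring. For the measured compounds named here, no pair measured shows a step of this kind, so there is nothing to calibrate it against. The step from compound 1 to compound 3 is expected to be small, a 1.1-fold lower number from compound 1 to compound 3 (0.05 log units; within the scatter), and not beyond the scatter in either direction. For compound 3 the value in this assay is estimated at 80000 nM, with a range from 30000 nM to 200000 nM.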

Compound 3, concentration for total growth inhibition: > 100000 nM
Compound 3 was reported as a limit; the forecaster's own chance of this, stated with the estimate: 20%; at least 1.2-fold (0.09 log units) between middle value and limit.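

In this assay compound 3 is reported only as a limit, > 100000 nM. The series now has its first one-place step, an at least 1.1-fold higher number from compound 1 to compound 3 (0.04 log units; that floor lies within the scatter), for benzyl in place of phenyl on a saturated chain carbon, three bonds along the chain from a nitrogen on an aromatic ring, and it gives no sign of stronger growth inhibition from this change. The true size of the step stays unread because the reading stops at a limit: the limit of > 100000 nM in this assay, at which 1 of the 3 values shown sits.

Still open, going by these compounds, is whether any group at this place brings the number down, for example a shorter chain ending in phenyl or an amine in place of the phenyl. Also open, on these data alone, is whether a carboxylic acid on the phenyl ring would move the number in either direction.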